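Indole-pyran dicarbonitriles: aryl swap at the saturated ring carbon

The source may hold more compounds than are shown below. What is called first, only, known or untested is meant among the compounds shown, and "the series" means these compounds.

Measured so far:
compound 1, `N#CC1=C(N)OC(c2c[nH]c3ccccc23)=C(C#N)C1c1ccc2ccccc2c1`: "not active" (no number reported)
compound 2, `COc1ccc(C2C(C#N)=C(N)OC(c3c[nH]c4ccccc34)=C2C#N)cc1`: 20%

In a functional assay, tested at 100 ug/mL (on this read-out lower numbers stand for a weaker effect and higher numbers for a stronger effect at the one concentration tested), compound 1 gives "not active" (no number reported), so compound 1 stands on no single number; all that is known is that it produced no reportable effect. In this assay compound 2 gives 20%, a weak read-out at the one concentration tested. Within the data shown here, the pair shows only that an aryl group other than naphthalen-2-yl on the saturated ring carbon can give a small but reported value.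

Compound 3, `N#CC1=C(N)OC(c2c[nH]c3ccccc23)=C(C#N)C1c1ccc(F)cc1`, has not yet been measured. The change is 4-fluorophenyl in place of naphthalen-2-yl on a saturated ring carbon. Among the measured compounds shown here, no measured step exists for this pair. Given that compound 1 had no reported number, a step in this assay of modest size, upward toward a weak reported effect, is expected, though it may stay within the scatter of an inactive call. Compound 3 is estimated at 15%, within 0% to 35%, resting on compound 2 at 20%.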

Compound 3, a percentage reported as activity, at one concentration (the size of the read-out at that concentration, not a potency): 16.2%
Compound 3: middle estimate off by 1.2 percentage points, on the low side; low and high end bracket the measured number.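

In this assay, 4-fluorophenyl in place of naphthalen-2-yl on the saturated ring carbon goes with a reported number: compound 3 gives 16.2%, while compound 1 gives "not active" (no number reported), and the step between these two cannot be read. Fluoro in place of methoxy on an aromatic carbon gives a number 3.8 percentage points lower from compound 2 to compound 3 (within the scatter), so this read-out does not separate these two aryl groups at the one concentration tested. No available evidence bears on either result.

On these data alone, it remains open whether an amine or a carboxylic acid on the aryl ring, or a cyclohexyl group in place of the aryl ring, would move the read-out beyond the scatter. A single concentration also leaves the potency of compound 2 and compound 3 unknown.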